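Series notes: nitro in place of methyl, compound 4 pending

The source may hold more compounds than are shown below. What is called first, only, known or untested is meant among the compounds shown, and "the series" means these compounds.

Compound 2 `Cc1ccc(N2C(=O)NC3(CC3(C)C)C2=O)cc1` stands level with compound 1 `CC1(C)CC12NC(=O)NC2=O` and compound 3 `CC1(C)CC12NC(=O)N(c1cc(Cl)cc(Cl)c1)C2=O` in a functional assay on the whole organism for inhibition, with Mus musculus as the target, in the maximal electroshock model, at a dose of 30 mg/kg by the oral route; on this read-out higher numbers stand for a stronger effect at the one dose given and lower numbers for a weaker effect: compound 2 gives 50%, compound 1 gives 50% and compound 3 gives 50%, all within the scatter of one another, so no order among the three can be read. Compound 4 `CC1(C)CC12NC(=O)N(c1ccc([N+](=O)[O-])cc1)C2=O` differs from compound 2 by nitro in place of methyl on an aromatic carbon, on an aromatic carbon of a six-membered aromatic ring of carbon only, para to a large group. Among the compounds with values here, no measured pair in the set shows what such a change does; the three measured compounds, which differ in what sits on the shared core, all sit at one level. The step expected here is no change at the digits printed from compound 2 to compound 4 (within the scatter), none beyond the scatter. Compound 4 is estimated at 50%, with a range from 30% to 70%.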

Compound 4, a percentage reported as inhibition, in the whole organism at one dose (the size of the read-out at that dose, not a potency): 60%
Estimate against measurement, compound 4: 10 percentage points below; measured number inside the range.
By their numbers in this assay, from the lowest: compounds 1, 2, 3 and 4 (each within the scatter of the next).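

Nitro in place of methyl on an aromatic carbon, para to a large group, gives in this assay a number 10 percentage points higher from compound 2 to compound 4 (within the scatter). This first one-place pair shows that this position accepts the larger nitro group, with its two hydrogen-bond acceptors, without a step beyond the scatter. No measurement on hand accounts for the size of this step.

Still open, as far as these compounds go, is whether any group at this position moves the read-out beyond the scatter, for example an amine or a carboxylic acid. A single dose also leaves potency unread for the whole series.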